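This account rests on a few compounds, and the source may have more. Where it says the series, first, only, none or still open, it means among the compounds named here.

Three compounds set the frame. Compound 1 `COc1cccc(Oc2ccc(NC(C)=O)cc2)c1` gives 4.1 nM in an assay on isolated protein for binding affinity to melatonin receptor type 1B (Homo sapiens) (a lower number here means a stronger inhibitor, a higher number a weaker inhibitor), compound 2 `CCC(=O)Nc1ccc(Oc2cccc(OC)c2)cc1` gives 6.8 nM, and compound 3 `CCC(=O)Nc1ccc(Nc2cccc(OC)c2)cc1` gives 1.8 nM, the lowest of the three numbers, with compound 1 its nearest neighbour and compound 2 the furthest. Compound 4 `CCCC(=O)Nc1ccc(Nc2cccc(OC)c2)cc1` differs from compound 3 by methyl in place of hydrogen on a saturated chain carbon, two bonds along the chain from a carbonyl carbon. Going by the values given here, the one measured step that bears on it is a 1.7-fold higher number from compound 1 to compound 2 (0.22 log units; within the scatter), where methyl replaced hydrogen on a saturated chain carbon bound to a carbonyl carbon and the number stayed within the scatter. For compound 4 no step beyond the scatter is therefore expected. The expected step is a 1.4-fold higher number from compound 3 to compound 4 (0.14 log units; within the scatter). Compound 4 is estimated at 2.5 nM, with a range from 1 nM to 6 nM.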

Compound 4, inhibition constant: 0.39 nM
Compound 4: middle estimate off by 6.4-fold (0.81 log units), on the high side; the measured number lies below the stated range.
By their numbers in this assay, from the lowest: compound 4; then compound 3; then compounds 1 and 2 (each within the scatter of the next).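

Going by these compounds alone, at this place, on a saturated chain carbon, two bonds along the chain from a carbonyl carbon, methyl in place of hydrogen gives a 4.6-fold lower number from compound 3 to compound 4 (0.66 log units; beyond the scatter) in this assay, the first step that lies beyond the scatter. Taking propanoyl to propylcarbonyl therefore lowers the number here, and adding methyl to this acyl chain has no single effect across the two cores: the same change on two cores in this assay, a 1.7-fold higher number (0.22 log units; within the scatter) from compound 1 to compound 2 and a 4.6-fold lower number (0.66 log units; beyond the scatter) from compound 3 to compound 4, 7.7-fold (0.88 log units) apart, beyond the scatter of two such steps.

From the compounds shown here alone, whether a longer chain or a terminal amine at this place would lower the number further remains open. The two steps differ in both core and chain place, so the contribution of each is unresolved.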